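A few compounds are considered here, and "the series" means these few. Any claim that something is new, unique, unknown or untested is made for them only; others in the source may bear on it.

Measured in a functional assay on J774 cells (Mus musculus) for cytotoxicity, read by resazurin assay; on this read-out lower numbers stand for stronger inhibition and higher numbers for weaker inhibition:
- compound 1 `OCCCCCC(O)c1ccc(-c2ccc(F)cc2)cc1`: 18000 nM
- compound 2 `OCCCCCC(O)c1ccc(-c2ccc(Cl)cc2Cl)cc1`: 8000 nM

Compound 1 holds the higher of the two numbers, and compound 2 lies lower by a gap beyond the usual scatter. The next compound, compound 3 `CCOc1ccc(-c2ccc(C(O)CCCCCO)cc2)cc1`, keeps the core of compound 1 and has ethoxy in place of fluoro on an aromatic carbon, para to a large group: ethoxy in place of fluoro on an aromatic carbon. Among the compounds with values here, no measured pair isolates a single change, so the guide is thin. The only span available is that of compound 1 at 18000 nM and compound 2 at 8000 nM. In this assay, a small move towards a lower number is expected, one that may not clear the scatter. The estimated step is a 1.6-fold lower number from compound 1 to compound 3 (0.21 log units; within the scatter). For compound 3 the expected value is 11000 nM, with an estimated range of 4500 nM to 27000 nM.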

Compound 3, half-maximal inhibitory concentration: 14000 nM
Compound 3: middle estimate off by 1.3-fold (0.10 log units), on the low side, and the stated range covers the measured number.
By their numbers in this assay, from the lowest: compounds 2, 3 and 1 (each within the scatter of the next, the first and the last beyond it).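

In this assay, within the data shown here, ethoxy in place of fluoro on an aromatic carbon, para to a large group, gives a 1.3-fold lower number from compound 1 to compound 3 (0.11 log units; within the scatter) and is the first change that can be read in isolation. Among these compounds, at this position, then, 3 heavy atoms and 1 hydrogen-bond acceptor enter in place of a single fluorine with no step that clears the scatter. No measured property bears on this result.

On these data alone, whether an amine, a carboxylic acid or a longer alkoxy chain such as butoxy at this position would give a step beyond the scatter remains open. Also open, as far as these compounds go, is how the number would respond to a change elsewhere on the core of compound 1, such as a ketone in place of the hydroxyl on the chain.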